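Aryl for propyl on the triazole of a quinoline series

A few compounds are considered here, and "the series" means these few. Any claim that something is new, unique, unknown or untested is made for them only; others in the source may bear on it.

Compound 1 `CCCCCCCc1cn(C(c2ccccc2)c2cc3cc(Br)ccc3nc2OC)nn1` gives 16.6% in an ADME assay on PANC-1 cells (Homo sapiens) for cytotoxicity, read by sulforhodamine B assay, with a stated time of 48 h, tested at 10 uM (a lower number here means less inhibition, a higher number more inhibition at the concentration tested (going by the name of the read-out)), and compound 2 `CCCc1cn(C(c2ccccc2)c2cc3cc(Br)ccc3nc2OC)nn1` gives 11.3%. Within the data shown here, the only measured step, a number 5.3 percentage points lower from compound 1 to compound 2 (within the scatter), changes the length of the chain on the triazole. Compound 2 thus stands lowest of the two numbers, but its nearest neighbour, compound 1, lies within the scatter of it, so no order between them can be read. Compound 3 `COc1nc2ccc(Br)cc2cc1C(c1ccccc1)n1cc(-c2ccc(OC(F)(F)F)cc2)nn1` differs from compound 2 by 4-(trifluoromethoxy)phenyl in place of propyl on an aromatic carbon. Among the measured compounds shown here, no measured step exchanges a chain for an aromatic group at this position; the one step in hand, a number 5.3 percentage points lower from compound 1 to compound 2 (within the scatter), shows that a change of chain length at the same carbon left the number within the scatter. The estimated step is therefore a number 6.7 percentage points higher from compound 2 to compound 3 (within the scatter), not expected to exceed the scatter. Compound 3 is expected to give 18%, between 4% and 38%.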

Compound 3, a percentage reported as inhibition, at one concentration (the size of the read-out at that concentration, not a potency): 11.7%
Compound 3: the middle estimate sits 6.3 percentage points above what was measured, within the range that was stated.
By their numbers in this assay, from the lowest: compounds 2, 3 and 1 (each within the scatter of the next).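

In this assay, among these compounds, a ring-bearing group stands for the first time on this aromatic carbon of the five-membered aromatic ring with 3 nitrogen, and the exchange for propyl gives a number 0.4 percentage points higher from compound 2 to compound 3 (within the scatter), while the exchange for heptyl gives a number 4.9 percentage points lower from compound 1 to compound 3 (within the scatter). The earlier compounds had shown only that a change of chain length at this carbon stayed within the scatter; these steps show that replacing either chain with 4-(trifluoromethoxy)phenyl does so as well. No measurement in hand offers an explanation for this.

Going by these compounds, whether a group of another kind on this carbon, such as an amine or a carboxylic acid, would move the number beyond the scatter remains open. So does whether a plain phenyl ring, without the trifluoromethoxy group, would give a similar number.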